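Fluoro to Methyl on the Aryl Piperazine Ring

The source may report more compounds than this note shows. Statements on the series, on what has been measured and on what is new or still open speak of the compounds shown alone.

Compound 1 `CCCc1nc(-c2ccccc2)c(CNCCN2CCN(c3ccc(F)cc3)CC2)o1`: 54.1%
Compound 2 `CCCc1nc(-c2ccccc2)c(CNCCN2CCN(c3ccc(C)cc3)CC2)o1`: 48.1%
Compound 3 `CCCc1nc(-c2ccccc2)c(CNCCCN2CCN(c3ccccc3F)CC2)o1`: 54.4%

These three compounds were measured in an assay on HEK293 cells for inhibition of Voltage-dependent T-type calcium channel subunit alpha-1G (Homo sapiens), read by fluorescence, tested at 10 uM; a lower number here means less inhibition, a higher number more inhibition at the concentration tested (going by the name of the read-out). Compound 1 and compound 2 share one core and differ in a single place: methyl in place of fluoro on an aromatic carbon. That change gave a number 6 percentage points lower from compound 1 to compound 2 (within the scatter), so the two values show no separation that the method can resolve. Compound 3 carries a different core, and the difference between the two cores is not broken down here; its value sits close to that of compound 1 and compound 2, all three within the usual scatter of one another.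

Compound 4 `CCCc1nc(-c2ccccc2)c(CNCCCN2CCN(c3ccccc3C)CC2)o1` has not yet been measured. It differs from compound 3 in one place: methyl in place of fluoro on an aromatic carbon. This is the same kind of change as that from compound 1 to compound 2, but not the same: in the first pair the swap is para to a large group, whereas in compound 3 and compound 4 it is ortho to a large group. Among the compounds with values here, the one measured precedent, the step from compound 1 to compound 2, stayed within the scatter, and no other data on this change exist.

On that basis the step is expected to be small, about a number 5.4 percentage points lower from compound 3 to compound 4 (within the scatter) in this assay, because the step from compound 1 to compound 2 was a number 6 percentage points lower from compound 1 to compound 2 (within the scatter). Compound 4 is therefore estimated at 49%, with a likely range from 36% to 61%.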

Compound 4, a percentage reported as inhibition, at one concentration (the size of the read-out at that concentration, not a potency): 54.5%
Compound 4: middle estimate off by 5.5 percentage points, on the low side; measured number inside the range.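

Methyl in place of fluoro on an aromatic carbon, here 2-fluorophenyl to 2-methylphenyl and ortho to a large group, gave a number 0.1 percentage points higher from compound 3 to compound 4 (within the scatter) in this assay. Set beside the earlier step, the change reads alike on the two cores, with no gap the method can resolve: the same change on two cores in this assay, a number 6 percentage points lower (within the scatter) from compound 1 to compound 2 and a number 0.1 percentage points higher (within the scatter) from compound 3 to compound 4, 6.1 percentage points apart, within the scatter of two such steps. Within the data shown here, this shows only that the swap of fluoro for methyl had no resolvable effect in either of these two pairs at the one concentration tested; it does not show that the change is without effect in general, that it would stay so on a third core, or that it would stay so at another concentration, and two steps that both lie within the scatter cannot reveal a small dependence on the core.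

The compounds shown leave open whether a chloro, methoxy or trifluoromethyl group on the same aromatic carbon would separate from fluoro and methyl in this read-out, and whether a longer chain between the two amine nitrogens would do so. They also leave open how the chain and the place of the group on the aromatic ring each contribute, as the two cores differ in both.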